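The compounds below may be only part of what the source reports. "The series", "measured", "known", "first", "only" and "open" are said of these compounds alone.

Measured compounds:
compound 1 `CCCCC[C@H](O)/C=C/[C@H]1OC[C@H](O)[C@@H]1C/C=C\CCCC(=O)O` gives 6700 nM
compound 2 `O=C(O)CCCC/C=C\C[C@H]1[C@@H](O)CO[C@@H]1/C=C/[C@@H](O)COc1cccc(C(F)(F)F)c1` gives 3100 nM

In an assay on isolated protein for binding affinity to prostaglandin F2-alpha receptor (Bos taurus) (on this read-out higher numbers stand for weaker inhibition and lower numbers for stronger inhibition), compound 2 gives 3100 nM, the lowest of the two numbers shown; compound 1 gives 6700 nM in this assay, and that gap lies beyond the scatter. The unmeasured compound 3 `O=C(O)CCCC/C=C\C[C@H]1[C@@H](O)CO[C@@H]1/C=C/[C@H](O)COc1cccc(C(F)(F)F)c1` is compared with compound 2 in this assay. The difference is the two compounds have the same atoms and bonds and differ only in configuration as drawn: 1 of 6 stereo elements differ; a stereocentre at a saturated chain carbon is drawn R in compound 2 and S in compound 3. Among the measured compounds shown here, no pair of measured compounds differing in a single stereocentre is available, so no measured step shows how such a change behaves here; the account therefore carries a wide range. Inversion at one stereocentre within otherwise identical compounds is expected to shift the inhibition constant, most likely towards weaker binding, and the step from compound 2 to compound 3 is estimated at a 2.6-fold higher number from compound 2 to compound 3 (0.41 log units; beyond the scatter). Compound 3 is expected to give about 8000 nM in this assay, within a range from 1500 nM to 40000 nM.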

Compound 3, inhibition constant: > 10000 nM
Compound 3: only a limit was reported; the forecaster's own chance of this, stated with the estimate: 10%; middle value at least 1.2-fold (0.09 log units) away from the limit.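

In this assay, among the compounds shown here, inverting the stereocentre at a saturated chain carbon from R to S gives an at least 3.2-fold higher number from compound 2 to compound 3 (0.50 log units; beyond the scatter), the first measured step at a single stereocentre. The value for compound 3 is a limit and not a number, so the step gives only a lower bound on the size of the change: the limit of > 10000 nM in this assay, at which 1 of the 3 values shown sits. Nothing else separates the pair, so the weaker binding can be traced to this one stereocentre alone: the fact that compounds 2 and 3 differ only in the configuration as drawn.

The compounds shown leave open how much weaker compound 3 really is, and whether the same inversion would have a similar effect on compound 1. They also leave open how an amine at that saturated chain carbon would behave in either configuration.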